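From a methylphenyl limit to an aminophenyl estimate

The compounds below may be only part of what the source reports. "The series", "measured", "known", "first", "only" and "open" are said of these compounds alone.

Measured in a functional assay on U-251 cells (Homo sapiens) for antiproliferative activity, read by MTT assay, with a stated time of 48 h; a lower number here means a stronger inhibitor, a higher number a weaker inhibitor:
- Compound 1 `COc1cc(-c2cccc3nc(-c4ccc(F)cc4)oc23)cc(OC)c1OC`: > 25000 nM (a limit)
- Compound 2 `COc1cc(-c2cccc3nc(-c4cccc(Br)c4)oc23)cc(OC)c1OC`: 6800 nM
- Compound 3 `COc1cc(-c2cccc3nc(-c4cccc(C)c4)oc23)cc(OC)c1OC`: > 25000 nM (a limit)

Compound 3 has no exact number, only a limit of > 25000 nM. This is the limit of > 25000 nM in this assay, at which 2 of the 3 values shown sit. Compound 1 shares that limit of > 25000 nM. Compound 2 alone gives a true number, 6800 nM.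

The next compound, compound 4 `COc1cc(-c2cccc3nc(-c4ccc(N)cc4)oc23)cc(OC)c1OC`, carries 4-aminophenyl in place of 3-methylphenyl on an aromatic carbon of a five-membered aromatic ring with 1 nitrogen and 1 oxygen: 4-aminophenyl in place of 3-methylphenyl on an aromatic carbon.

Three measured steps change this same group. Putting 3-bromophenyl in place of 4-fluorophenyl gave an at least 3.6-fold lower number from compound 1 to compound 2 (0.56 log units; beyond the scatter). Putting methyl in place of bromo gave an at least 3.6-fold higher number from compound 2 to compound 3 (0.56 log units; beyond the scatter). Putting 3-methylphenyl in place of 4-fluorophenyl gave a step that the two limits leave unreadable from compound 1 to compound 3. So the one readable change in this series is modest in its measured size, and it runs in both directions. Among the compounds with values here, no compound with an amino group has been measured yet.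

A modest move towards a lower number is therefore expected, though compound 4 may well stay at the limit. The expected change is an at least 1.6-fold lower number from compound 3 to compound 4 (0.22 log units; that floor lies within the scatter). For compound 4 the estimate is 15000 nM, with an expected range from 5000 nM to 40000 nM.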

Compound 4, half-maximal inhibitory concentration: 1040 nM
For compound 4 the middle estimate is 14-fold (1.16 log units) above the measured one; the whole stated range lies above it.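

In this assay, the aromatic carbon next to the ring nitrogen and next to the ring oxygen proves able to carry a far stronger compound than the earlier three suggested: with 4-aminophenyl in place of 3-methylphenyl there is an at least 24-fold lower number from compound 3 to compound 4 (1.38 log units; beyond the scatter) and with it in place of 3-bromophenyl there is a 6.5-fold lower number from compound 2 to compound 4 (0.82 log units; beyond the scatter) so compound 4 is the strongest of the four. The closest comparison keeps the substituent at the same spot on the phenyl ring and changes only amino for fluoro, giving an at least 24-fold lower number from compound 1 to compound 4 (1.38 log units; beyond the scatter) and showing that the choice of this one substituent can separate a compound at the limit from one with a measured value. From the compounds shown here alone, the true sizes of the two large steps stay unknown because each starts from a limit rather than a number: the limit of > 25000 nM in this assay, at which 2 of the 4 values shown sit.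

A 3-aminophenyl group would show whether the amino group must sit where it does in compound 4. A 4-hydroxyphenyl or 4-dimethylaminophenyl group would show whether the gain needs an amino group with its hydrogens or extends to related substituents.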